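Swapping the Aryl Group at the Triazole of Compound 3

The source may report more compounds than this note shows. Statements on the series, on what has been measured and on what is new or still open speak of the compounds shown alone.

Three compounds share a core and differ only in the aromatic group attached to the five-membered ring with three nitrogens. Compound 1, `O=C(NO)c1ccc(NCc2nc(-c3cccc4cnccc34)nn2-c2ccccc2)cc1`, carries an isoquinolin-5-yl group and gives 40.2% in an assay on Sf9 cells for inhibition of protein deacetylase HDAC6 (Homo sapiens), read by fluorescence, with a stated time of 40 min, tested at 100 nM; a higher number here means more inhibition at the concentration tested (going by the name of the read-out), a lower number less inhibition. Compound 2, `O=C(NO)c1ccc(NCc2nc(-c3ccc(Br)cc3)nn2-c2ccccc2)cc1`, with a 4-bromophenyl group, gives 54.7%, and compound 3, `O=C(NO)c1ccc(NCc2nc(-c3ccc(Cl)cc3)nn2-c2ccccc2)cc1`, with a 4-chlorophenyl group, gives 67.2%. Compound 3 stands highest of the three: the step of a number 27 percentage points higher from compound 1 to compound 3 (beyond the scatter) is beyond the scatter, as is the smaller step of a number 12.5 percentage points higher from compound 2 to compound 3 (beyond the scatter).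

Compound 4, `Cc1ccccc1-c1nc(CNc2ccc(C(=O)NO)cc2)n(-c2ccccc2)n1`, is not yet measured. The change from compound 3 is 2-methylphenyl in place of 4-chlorophenyl on an aromatic carbon. Among the compounds with values here, no measured step covers a 2-methylphenyl group, so only an indirect reading is possible. The steps of a number 14.5 percentage points higher from compound 1 to compound 2 (beyond the scatter) and a number 12.5 percentage points higher from compound 2 to compound 3 (beyond the scatter) show that the group at this aromatic carbon moves the read-out by modest amounts, and the 4-chlorophenyl group of compound 3 gave the highest value seen. Leaving it for an untested group is therefore expected to lower the number somewhat, by about a number 17.2 percentage points lower from compound 3 to compound 4 (beyond the scatter), though the direction is uncertain. Compound 4 is estimated at 50%, with a range from 30% to 70%.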

Compound 4, a percentage reported as inhibition, at one concentration (the size of the read-out at that concentration, not a potency): 53.2%
Beside the measured number, compound 4's estimate is 3.2 percentage points below it; measured number inside the range.
By their numbers in this assay, from the lowest: compound 1; then compounds 4 and 2 (each within the scatter of the next); then compound 3.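

Compound 3 stays the highest of the four: with 2-methylphenyl in place of 4-chlorophenyl on this aromatic carbon, this assay gives a number 14 percentage points lower from compound 3 to compound 4 (beyond the scatter) and shows that the earlier lead of the 4-chlorophenyl group also holds against a phenyl ring carrying a methyl group. Against the bromo compound the result is a number 1.5 percentage points lower from compound 2 to compound 4 (within the scatter) so 2-methylphenyl and 4-bromophenyl cannot be told apart here, while a number 13 percentage points higher from compound 1 to compound 4 (beyond the scatter) shows that a phenyl ring without any halogen can also stand clear of isoquinolin-5-yl, so among these four a halogen is not needed for that. Nothing measured here explains any of these differences.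

This one swap changes both the substituent and where it sits on the phenyl ring, so the compounds shown cannot say which of the two matters for the gap to compound 3. A 2-chlorophenyl or a 4-methylphenyl group at the same carbon would separate the two, and a plain phenyl group would show what the substituents add at all.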